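The source may hold more compounds than are shown below. What is called first, only, known or untested is meant among the compounds shown, and "the series" means these compounds.

Measured compounds in a functional assay on MCF7 cells (Homo sapiens) for antiproliferative activity, read by MTT assay; on this read-out lower numbers stand for stronger inhibition and higher numbers for weaker inhibition:
compound 1, `c1ccc2c(c1)ccn2-c1nc(N2CCNCC2)nc2ccccc12`, gives 14.1 ug/mL
compound 2, `CN1CCN(c2nc(-n3ccc4ccccc43)c3ccccc3n2)CC1`, gives 6 ug/mL
compound 3, `Cn1cc(-c2nc(N3CCNCC3)nc3ccccc23)c2ccccc21`, gives 50 ug/mL

Compound 1 and compound 2 share one core; compound 3 rests on a different one, and how the core of compound 3 differs from that of compound 1 is not broken down here. Compound 3 gives the highest number of the three in this assay, and its distance from compound 1 and from compound 2 lies beyond the scatter. For the measured compounds named here, the one change that has already been measured is methyl in place of hydrogen on an amine nitrogen in a ring; in this assay it gave a 2.4-fold lower number from compound 1 to compound 2 (0.37 log units; beyond the scatter).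

Compound 4, `CN1CCN(c2nc(-c3cn(C)c4ccccc34)c3ccccc3n2)CC1`, is not yet measured. It differs from compound 3 by methyl in place of hydrogen on an amine nitrogen in a ring, the same change at the same place, now made on the core of compound 3 rather than that of compound 1. Because a 2.4-fold lower number from compound 1 to compound 2 (0.37 log units; beyond the scatter) was modest yet beyond the scatter, a step of comparable size is expected from compound 3 to compound 4, estimated at a 2.4-fold lower number from compound 3 to compound 4 (0.38 log units; beyond the scatter). This rests on a single earlier instance on another core, so the expectation is held loosely. Compound 4 is expected to give about 21 ug/mL in this assay, most likely between 10 ug/mL and 42 ug/mL.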

Compound 4, half-maximal inhibitory concentration: 50 ug/mL
Estimate against measurement, compound 4: 2.4-fold (0.38 log units) below; the whole stated range lies below it.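

In this assay, putting methyl in place of hydrogen on the amine nitrogen of the ring, which turns piperazin-1-yl into 4-methylpiperazin-1-yl, gave no change at the digits printed from compound 3 to compound 4 (within the scatter). Set beside the earlier instance of this change, the new step cannot be told apart from it: the same change on two cores in this assay, a 2.4-fold lower number (0.37 log units; beyond the scatter) from compound 1 to compound 2 and no change at the digits printed (within the scatter) from compound 3 to compound 4, 2.4-fold (0.37 log units) apart, within the scatter of two such steps The lower number seen on the core of compound 1 did not reappear on the core of compound 3, yet the gap between the two steps is too small to show that the core alters what the methyl does, and with a single pair on each core the result neither shows that the change carries over nor shows that it fails to.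

The compounds shown leave open how a longer chain such as ethyl or propyl, or an acyl group such as acetyl, on the same ring nitrogen would read on either core. They also leave open whether replacing the whole piperazine with another amine, such as morpholine, would separate the two cores more clearly than the methyl does.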